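Aryl swap on the shared core: compound 1 to compound 3

A few compounds are considered here, and "the series" means these few. Any claim that something is new, unique, unknown or untested is made for them only; others in the source may bear on it.

Compound 1 `O=C(O)Cc1sc(C(c2ccc(F)cc2)c2ccc(F)cc2)nc1-c1ccccc1` stands at the higher end of the two numbers recorded so far: in an in vitro functional assay on HEK285-7 cells for antagonist activity at prostaglandin D2 receptor 2 (Homo sapiens), read by BRET and beta-arrestin recruitment (a higher number here means a weaker inhibitor, a lower number a stronger inhibitor), compound 1 gives 240 nM. Going by the values given here, compound 2 `O=C(O)Cc1sc(C(c2ccccc2)c2ccccc2)nc1-c1ccc(F)c(F)c1` differs from compound 1 in more than one place, so no single step connects the two; in this assay compound 2 gives 43 nM, a lower number than compound 1 and a gap beyond the scatter. Compound 3 `O=C(O)Cc1sc(C(c2ccc(F)cc2)c2ccc(F)cc2)nc1-c1ccnc(Cl)c1` has not been measured. It departs from compound 1 in one place only: 2-chloropyridin-4-yl in place of phenyl on an aromatic carbon. Among the compounds with values here, no measured pair shows this exact change, so its size is uncertain. Within the data shown here, the single comparison available, compound 2 against compound 1, shows that a different group at this place can go with a lower number, but compound 2 also alters the other part of the structure, so it cannot be read as a step for this change. The expectation is a modest move downward, within the scatter or just beyond it. The estimate for compound 3 in this assay is 150 nM, with a range from 50 nM to 500 nM. The expected step is a 1.6-fold lower number from compound 1 to compound 3 (0.20 log units; within the scatter).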

Compound 3, half-maximal inhibitory concentration: 39 nM
Beside the measured number, compound 3's estimate is 3.8-fold (0.59 log units) above it, and the stated range ends above it.
By their numbers in this assay, from the lowest: compounds 3 and 2 (each within the scatter of the next); then compound 1.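

In this assay, the aromatic carbon next to the ring nitrogen now has a step that reads on its own: 2-chloropyridin-4-yl in place of phenyl gives a 6.2-fold lower number from compound 1 to compound 3 (0.79 log units; beyond the scatter) and lies beyond the scatter, with the rest of the core of compound 1 unchanged. Going by these compounds alone, until now, the only comparison touching this place also altered another part of the structure, so this is the first sign that the place alone can move the number. It also shows that a ring with a hetero atom and a chlorine is tolerated here with no loss in this assay, and nothing measured alongside these numbers speaks to what lies behind the step.

From the compounds shown here alone, how the step divides between the ring nitrogen and the chlorine stays open, as both entered together; a plain pyridin-4-yl and a chlorophenyl at this place would separate the two. Also open, going by these compounds, is whether an amine or a methoxy group in place of the chlorine would keep the lower number.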